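Methoxyphenyl sulfonate esters: a positional swap with no anchor

A few compounds are considered here, and "the series" means these few. Any claim that something is new, unique, unknown or untested is made for them only; others in the source may bear on it.

Compound 1 `CCN1CCN(c2ccc(S(=O)(=O)Oc3ccccc3OC)cc2)C1=O` gives > 100000 nM in a functional assay on HT-29 cells (Homo sapiens) for antiproliferative activity, read by sulforhodamine B assay, with a stated time of 48 h; a lower number here means a stronger inhibitor, a higher number a weaker inhibitor; this value is a limit of the assay.
Compound 2 `CCCN1CCN(c2ccc(S(=O)(=O)Oc3ccccc3OC)cc2)C1=O` gives > 100000 nM in this assay; this value is also a limit of the assay.

Because both sit at the limit of > 100000 nM in this assay, at which 2 of the 2 values shown sit, the step that the two limits leave unreadable from compound 1 to compound 2 cannot be read, and compound 2 stands only at a limit. Compound 3 `CCCN1CCN(c2ccc(S(=O)(=O)Oc3ccc(OC)cc3)cc2)C1=O` differs from compound 2 by 4-methoxyphenyl in place of 2-methoxyphenyl on an oxygen. Among the measured compounds shown here, no measured step bears on this change. Compound 3 is therefore expected to stay at the limit, with an estimated 100000 nM spanning 30000 nM to 300000 nM. The expected step of a number no higher from compound 2 to compound 3 (the limit leaves the size open) is none beyond the scatter.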

Compound 3, half-maximal inhibitory concentration: 16000 nM
The estimate for compound 3 lay 6.3-fold (0.80 log units) above the measured number; measured number outside the range, below it.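

In this assay, compound 3 is the only compound shown with a readable number, and 4-methoxyphenyl in place of 2-methoxyphenyl on the oxygen gives an at least 6.2-fold lower number from compound 2 to compound 3 (0.79 log units; beyond the scatter). The two compounds have the same atoms joined differently, so the placing of the methoxy group alone separates a limit from a measured number. The full size of the step stays open because compound 2 stands only at a limit: the limit of > 100000 nM in this assay, at which 2 of the 3 values shown sit.

As far as these compounds go, whether an amine or a carboxylic acid in place of the methoxy group would keep this activity remains open. So does whether 4-methoxyphenyl would give a readable number on the core of compound 1.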